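The source may hold more compounds than are shown below. What is called first, only, known or untested is meant among the compounds shown, and "the series" means these compounds.

Measured so far:
Compound 1 `CC(C)(C)C#Cc1cc(N(C(=O)[C@H]2CC[C@H](C)CC2)[C@H]2CC[C@H](OC3CCOC3)CC2)c(C(=O)O)s1` gives 3.5 h in an ADME assay on the whole organism (strain Sprague-Dawley) with Rattus norvegicus as the target, at a dose of 0.5 mg/kg by the intravenous route; a higher number here means that the compound lasts longer, a lower number that the compound disappears faster.
Compound 2 `CC(C)(C)C#Cc1cc(N(C(=O)[C@H]2CC[C@H](C)CC2)[C@H]2CC[C@](O)(CO[C@H]3CCOC3)CC2)c(C(=O)O)s1` gives 3.8 h in this assay.

Compound 1 has the lower of the two numbers, but compound 2 sits so close that the two cannot be told apart within the usual scatter. Compound 3 `CC(C)(C)C#Cc1cc(N(C(=O)[C@H]2CC[C@H](C)CC2)[C@H]2CC[C@H](Oc3ccc(=O)[nH]n3)CC2)c(C(=O)O)s1` has not been measured yet. It differs from compound 1 in one place: a group of 7 heavy atoms (4 carbon, 2 nitrogen, 1 oxygen; one six-membered aromatic ring with 2 hetero atoms) in place of a group of 5 heavy atoms (4 carbon, 1 oxygen; one five-membered non-aromatic ring with 1 hetero atom), on an oxygen on a saturated carbon. For the measured compounds named here, no measured pair shows a change of this kind, so there is nothing to set the size of the step from. The expectation is a step that stays within the scatter, with no clear direction, so compound 3 is expected to give 3 h in this assay, somewhere between 1.5 h and 6 h. This expectation means a step of a 1.2-fold lower number from compound 1 to compound 3 (0.07 log units; within the scatter).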

Compound 3, mean residence time: 1.6 h
For compound 3 the middle estimate is 1.9-fold (0.27 log units) above the measured one; measured number inside the range.
By their numbers in this assay, from the lowest: compound 3; then compounds 1 and 2 (each within the scatter of the next).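

On an oxygen on a saturated carbon, replacing oxolan-3-yl with the six-membered aromatic ring with 2 hetero atoms gives a 2.2-fold lower number from compound 1 to compound 3 (0.34 log units; beyond the scatter) in this assay. For the compounds shown here, this modest step is the first one available here, and it shows that the number can respond to the group at this position. Nothing measured here gives a reason for the step. One pair cannot show which part of the new ring matters, the carbonyl or the ring nitrogens. A plain phenyl ring or a pyridine ring on the same oxygen could separate these parts.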